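Stability notes: removing the sulfonamide arm of compound 3

This account rests on a few compounds, and the source may have more. Where it says the series, first, only, none or still open, it means among the compounds named here.

Compound 3 `O=c1cc(N2CCN(CC3CCC(NS(=O)(=O)c4ccccc4)CC3)CC2)sc2c([N+](=O)[O-])cc(C(F)(F)F)cc12` gives 90.8% in an ADME assay on cells (Hepatocyte, Homo sapiens) for metabolic stability, with a stated time of 30 min (on this read-out lower numbers stand for a less stable compound and higher numbers for a more stable compound), the highest of the three numbers: compound 2 `Cc1ccc(C(=O)OC2CCC(CN3CCN(c4cc(=O)c5cc(C(F)(F)F)cc([N+](=O)[O-])c5s4)CC3)CC2)cc1` gives 9.7% and compound 1 `O=C(OC1CCC(CN2CCN(c3cc(=O)c4cc(C(F)(F)F)cc([N+](=O)[O-])c4s3)CC2)CC1)c1cccs1` gives 2.2%. Compound 4 `O=c1cc(N2CCN(CC3CCCCC3)CC2)sc2c([N+](=O)[O-])cc(C(F)(F)F)cc12` differs from compound 3 by hydrogen in place of (phenylsulfonyl)amino on a saturated ring carbon. Among the compounds with values here, the steps that bear on it are a number 88.6 percentage points higher from compound 1 to compound 3 (beyond the scatter) and a number 81.1 percentage points higher from compound 2 to compound 3 (beyond the scatter), both large and in favour of the (phenylsulfonyl)amino compound; a number 7.5 percentage points higher from compound 1 to compound 2 (within the scatter) is small. Within the data shown here, no measured step exchanges (phenylsulfonyl)amino for hydrogen, so the direction rests on the high standing of compound 3 alone. A decrease beyond the scatter is expected, though smaller than the two large steps just described. The step for compound 4 is estimated as a number 40.8 percentage points lower from compound 3 to compound 4 (beyond the scatter). Compound 4 is therefore estimated at 50%, between 15% and 85%.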

Compound 4, percent of the compound remaining: 82.4%
The estimate for compound 4 lay 32.4 percentage points below the measured number, within the range that was stated.
By their numbers in this assay, from the lowest: compounds 1 and 2 (each within the scatter of the next); then compounds 4 and 3 (each within the scatter of the next).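

In this assay the step of a number 8.4 percentage points lower from compound 3 to compound 4 (within the scatter) for hydrogen in place of (phenylsulfonyl)amino on a saturated ring carbon shows that the high number does not depend on that arm. The steps of a number 72.7 percentage points higher from compound 2 to compound 4 (beyond the scatter) and a number 80.2 percentage points higher from compound 1 to compound 4 (beyond the scatter) for hydrogen in place of the two carbonyloxy groups place the low numbers with those ester groups and not with the unsubstituted ring. Nothing available here explains these numbers. Going by these compounds, whether a small group on this ring carbon, such as an amine, a carboxylic acid or an amide, keeps the number of compound 4 stays open.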